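Methoxy in place of hydrogen on the core of compound 1

This account rests on a few compounds, and the source may have more. Where it says the series, first, only, none or still open, it means among the compounds named here.

Compound 1 `Oc1ccccc1/C=N/NC(=S)N1CCOCC1` is the parent of the series. In a functional assay on MCF7 cells (Homo sapiens) for antiproliferative activity, read by MTT assay, with a stated time of 72 h (on this read-out lower numbers stand for stronger inhibition and higher numbers for weaker inhibition), compound 1 gives > 64000 nM, which is a limit of the assay and not a number. Compound 2 `Oc1ccc(Cl)cc1/C=N/NC(=S)N1CCOCC1` carries chloro in place of hydrogen on an aromatic carbon; in this assay compound 2 gives > 64000 nM, again a limit. Compound 3 `Oc1c(Br)cc(Br)cc1/C=N/NC(=S)N1CCOCC1` in this assay gives > 64000 nM, also a limit. Compound 1 thus stands at the limit together with the other two, and no ordering among them can be read.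

Compound 4 `COc1ccc(/C=N/NC(=S)N2CCOCC2)c(O)c1` differs from compound 1 by methoxy in place of hydrogen on an aromatic carbon. For the measured compounds named here, the only measured step that bears on this change is a step that the two limits leave unreadable from compound 1 to compound 2, which has no readable size because of the limit of > 64000 nM in this assay, at which 3 of the 3 values shown sit. On this basis no step beyond the scatter can be expected in this assay in either direction, and the most probable outcome is that compound 4 again returns only a limit. The estimate for compound 4 is 80000 nM, with a range from 25000 nM to 300000 nM, which means an expected step that the limit leaves unreadable from compound 1 to compound 4 of no readable size.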

Compound 4, half-maximal inhibitory concentration: > 64000 nM
Compound 4: no number, only a limit (the forecaster's own chance of this, stated with the estimate: 80%); the middle value does not contradict the limit.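

No new step can be read between compound 1 and compound 4, as both return only a limit of the assay and not a number: the limit of > 64000 nM in this assay, at which 4 of the 4 values shown sit.

The compounds shown leave open whether any change on the shared core gives a readable value in this assay.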